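Ethynyl in place of a fluorophenyl triazole

A few compounds are considered here, and "the series" means these few. Any claim that something is new, unique, unknown or untested is made for them only; others in the source may bear on it.

In a functional assay on U-87MG ATCC cells for antiproliferative activity against U-87 MG (Homo sapiens), read by MTT assay, with a stated time of 48 h (a higher number here means a weaker inhibitor, a lower number a stronger inhibitor), compound 1 `C/C(=C\CC/C(C)=C/CC[C@@H]1[C@@]2(C)CCC(=O)C(C)(C)[C@H]2CC[C@@]1(C)O)CC/C=C(\C)C(=O)OCc1cn(-c2ccc(F)cc2)nn1` gives > 150000 nM as a limit of the assay and not a number. In this assay compound 2 `C/C(=C\CC/C(C)=C/CC[C@@H]1[C@@]2(C)CCC(=O)C(C)(C)[C@H]2CC[C@@]1(C)O)CC/C=C(\C)C(=O)OCc1cn(C[C@@H]2O[C@H](n3ccc(=O)[nH]c3=O)C[C@H]2O)nn1` gives 75800 nM as a measured number. Compound 3 `C#CCOC(=O)/C(C)=C/CC/C(C)=C/CC/C(C)=C/CC[C@@H]1[C@@]2(C)CCC(=O)C(C)(C)[C@H]2CC[C@@]1(C)O` has ethynyl in place of 1-(4-fluorophenyl)-1H-1,2,3-triazol-4-yl on a saturated chain carbon bound to an oxygen next to a carbonyl group. Among the compounds with values here, no measured step exists to size this change, and compound 2 at 75800 nM is the only number to lean on. The expected at least 1.5-fold lower number from compound 1 to compound 3 (0.17 log units; that floor lies within the scatter) is small and toward stronger inhibition, if it exceeds the scatter at all. In this assay compound 3 is estimated at 100000 nM with an expected range from 40000 nM to 200000 nM for its reading.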

Compound 3, half-maximal inhibitory concentration: > 150000 nM
Compound 3: a limit, no number (the forecaster's own chance of this, stated with the estimate: 45%); middle value at least 1.5-fold (0.17 log units) from the limit.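

Within the data shown here, no step from compound 1 to compound 3 can be read in this assay, because both readings are limits and not numbers: the limit of > 150000 nM in this assay, at which 2 of the 3 values shown sit. On these data alone, whether ethynyl or 1-(4-fluorophenyl)-1H-1,2,3-triazol-4-yl gives the stronger inhibition in this assay stays open.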